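This account rests on a few compounds, and the source may have more. Where it says the series, first, only, none or still open, it means among the compounds named here.

Notes on a series that shares one core and varies only the aryl group on a carbon with a double bond to nitrogen. In a functional assay on MCF7 cells (Homo sapiens) for inhibition, read by MTT assay, with a stated time of 48 h (a lower number here means a stronger inhibitor, a higher number a weaker inhibitor), compound 1 `O=C(CSc1nnc(-c2ccncc2)n1-c1ccccc1)N/N=C/c1ccc(Cl)cc1` gives 9930 nM. Compound 2 `O=C(CSc1nnc(-c2ccncc2)n1-c1ccccc1)N/N=C/c1ccc(F)cc1` gives 12300 nM in this assay, and compound 3 `O=C(CSc1nnc(-c2ccncc2)n1-c1ccccc1)N/N=C/c1ccccc1F` gives 22400 nM. Compound 3 thus carries the highest of the three numbers: its nearest neighbour is compound 2, with a 1.8-fold higher number from compound 2 to compound 3 (0.26 log units; within the scatter), which stays within the scatter, and its furthest is compound 1, with a 2.3-fold higher number from compound 1 to compound 3 (0.35 log units; beyond the scatter), a modest step beyond the scatter. The halogen exchange at one place, a 1.2-fold higher number from compound 1 to compound 2 (0.09 log units; within the scatter), also stays within the scatter.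

Compound 4 `O=C(CSc1nnc(-c2ccncc2)n1-c1ccccc1)N/N=C/c1cccc(F)c1` awaits measurement. Its change from compound 3 is 3-fluorophenyl in place of 2-fluorophenyl on a carbon with a double bond to nitrogen. Among the compounds with values here, two measured steps bear on it: a 1.8-fold higher number from compound 2 to compound 3 (0.26 log units; within the scatter), the only shift of a fluorine between two fluorophenyl groups on record, and a 2.3-fold higher number from compound 1 to compound 3 (0.35 log units; beyond the scatter). Both are small, and the fluorophenyl-to-fluorophenyl shift stays within the scatter. The 3-fluorophenyl group is therefore expected to give a number close to that of compound 3, with no step beyond the scatter in either direction. The expected step is a 1.4-fold lower number from compound 3 to compound 4 (0.15 log units; within the scatter). Compound 4 is estimated at 16000 nM, in a range from 8000 nM to 35000 nM in this assay.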

Compound 4, half-maximal inhibitory concentration: > 50000 nM
Compound 4 was reported as a limit; the forecaster's own chance of this, stated with the estimate: 5%; middle value at least 3.1-fold (0.49 log units) away from the limit.
By their numbers in this assay, from the lowest: compounds 1, 2 and 3 (each within the scatter of the next, the first and the last beyond it). At a limit, above all of these: compound 4.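

Compound 4 is reported in this assay only as a limit, not as a number: the limit of > 50000 nM in this assay, at which 1 of the 4 values shown sits. Even read from that limit, moving the fluorine on the aryl group at this carbon is not a neutral change: an at least 2.2-fold higher number from compound 3 to compound 4 (0.34 log units; beyond the scatter) and an at least 4.0-fold higher number from compound 2 to compound 4 (0.60 log units; beyond the scatter), whereas the only earlier exchange between two fluorophenyl groups, a 1.8-fold higher number from compound 2 to compound 3 (0.26 log units; within the scatter), stayed within the scatter. With an at least 5.0-fold higher number from compound 1 to compound 4 (0.70 log units; beyond the scatter) as well, the 3-fluorophenyl group stands apart from all three earlier aryl groups, so among these four compounds a rearrangement of the same atoms in the aryl group is enough to carry the number beyond the scatter, a sensitivity that the close values of compounds 1, 2 and 3 did not reveal.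

On these data alone, how far compound 4 lies past its limit remains open, and with it the true size of these three steps. Also open, as far as these compounds go, is whether the 3-fluorophenyl result belongs to fluorine alone or extends to other groups on the aryl ring, such as a 3-chlorophenyl, a methoxy group, an amine or a carboxylic acid.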